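The compounds below may be only part of what the source reports. "The series", "measured", "known", "first", "only" and "open" are said of these compounds alone.

Measured compounds:
compound 1, `Cc1nc2c(Br)c(Br)c(Br)c(Br)c2n1CCCCC#N`, in a functional assay on CCRF-CEM cells (Homo sapiens) for cytotoxicity, read by MTT assay, with a stated time of 24 h, tested at 10 uM (a higher number here means a weaker effect of the compound at the concentration tested, a lower number a stronger effect), compound 1 gives 92%
compound 2, `Cc1nc2c(Br)c(Br)c(Br)c(Br)c2n1CCCC#N`, in this assay compound 2 gives 68%
compound 3, `N#CCCCCn1cnc2c(Br)c(Br)c(Br)c(Br)c21`, in this assay compound 3 gives 98%

Compound 4, `N#CCCCn1cnc2c(Br)c(Br)c(Br)c(Br)c21`, has not yet been measured in this assay. It differs from compound 3 by cyano in place of cyanomethyl on a saturated chain carbon, three bonds along the chain from an aromatic nitrogen. The same change is already measured once, from compound 1 to compound 2, (cyano in place of cyanomethyl on a saturated chain carbon, three bonds along the chain from an aromatic nitrogen), where it gave a number 24 percentage points lower from compound 1 to compound 2 (beyond the scatter). The two cores differ by hydrogen in place of methyl on an aromatic carbon, and that change gave a number 6 percentage points higher from compound 1 to compound 3 (within the scatter), so compound 3 and compound 1 are not separated in this assay. For the measured compounds named here, since the place of the chain shortening is the same in words for both pairs, the step from compound 3 to compound 4 is expected to be of similar size to the one from compound 1 to compound 2; this rests on a single measured instance, so the expectation is loose. The expected step is a number 24 percentage points lower from compound 3 to compound 4 (beyond the scatter). For compound 4 in this assay the estimate is 74%, with a likely range from 58% to 92%.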

Compound 4, a percentage reported as activity, at one concentration (the size of the read-out at that concentration, not a potency): 85%
Estimate against measurement, compound 4: 11 percentage points below, within the range that was stated.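

In this assay, going from 4-cyanobutyl to 3-cyanopropyl gives a number 13 percentage points lower from compound 3 to compound 4 (beyond the scatter), and this step agrees with the one measured on the core of compound 1: the same change on two cores in this assay, a number 24 percentage points lower (beyond the scatter) from compound 1 to compound 2 and a number 13 percentage points lower (beyond the scatter) from compound 3 to compound 4, 11 percentage points apart, within the scatter of two such steps. Hydrogen in place of methyl on an aromatic carbon gives a number 17 percentage points higher from compound 2 to compound 4 (beyond the scatter), and although only this step of the pair lies beyond the scatter, the two cannot be told apart: the same change on two cores in this assay, a number 6 percentage points higher (within the scatter) from compound 1 to compound 3 and a number 17 percentage points higher (beyond the scatter) from compound 2 to compound 4, 11 percentage points apart, within the scatter of two such steps. The chain shortening therefore carries over between these two cores in direction and, within the scatter, in size, but the four compounds do not show that it would hold on any other core, and since both comparisons rest on the same four values, the second is no independent confirmation of the first.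

Open, from the compounds shown here alone, is whether the trend continues to 2-cyanoethyl or cyanomethyl, or reverses with a longer chain such as 5-cyanopentyl. Also open, going by these compounds, is how the series responds when an amine or a carboxylic acid takes the place of the nitrile at the chain end.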